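The source may hold more compounds than are shown below. What is called first, only, known or untested is meant among the compounds shown, and "the series" means these compounds.

Measured compounds:
compound 1 `O=C1CC(c2c(-c3ccc[nH]3)[nH]c3ccccc23)C(=O)N1`, 9000 nM in a functional assay on PC-3 cells (Homo sapiens) for cytotoxicity, read by MTT assay, with a stated time of 72 h; on this read-out higher numbers stand for weaker inhibition and lower numbers for stronger inhibition
compound 2 `Cc1ccc2[nH]c(-n3cccn3)c(C3=C(Br)C(=O)NC3=O)c2c1`, 26000 nM in this assay
compound 3 `O=C1NC(=O)C(c2c(-n3cccn3)[nH]c3ccccc23)=C1Br`, 27000 nM in this assay

Compound 1 gives the lowest number of the three; compound 2 and compound 3 sit close together. The difference between the core of compound 1 and the core of compound 3 is not broken down here.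

Within the core of compound 3, one change is measured: methyl in place of hydrogen on an aromatic carbon. This gives a 1.0-fold lower number from compound 3 to compound 2 (0.02 log units; within the scatter), a step within the scatter.

Compound 4 `Cc1ccc2[nH]c(-c3ccc[nH]3)c(C3CC(=O)NC3=O)c2c1` is not yet measured. It carries the same change on the core of compound 1: methyl in place of hydrogen on an aromatic carbon. The two place descriptions agree word for word, so the change is the same.

Because a 1.0-fold lower number from compound 3 to compound 2 (0.02 log units; within the scatter) shows no movement, compound 4 is expected to stay near compound 1 in this assay, with an estimated step of no change at the digits printed from compound 1 to compound 4 (within the scatter). Compound 4 is estimated at 9000 nM, expected between 4000 nM and 20000 nM.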

Compound 4, half-maximal inhibitory concentration: 11000 nM
Compound 4: middle estimate off by 1.2-fold (0.09 log units), on the low side, within the range that was stated.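

In this assay, methyl in place of hydrogen on an aromatic carbon gives a 1.2-fold higher number from compound 1 to compound 4 (0.09 log units; within the scatter), and the two cores show no difference in how they take this change: the same change on two cores in this assay, a 1.0-fold lower number (0.02 log units; within the scatter) from compound 3 to compound 2 and a 1.2-fold higher number (0.09 log units; within the scatter) from compound 1 to compound 4, 1.3-fold (0.10 log units) apart, within the scatter of two such steps

Carrying this change from one core to the other therefore holds in this assay, but only as two steps that both stay within the scatter. This does not show that a step large enough to exceed the scatter would carry across these cores in the same way, nor does it extend to other cells.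

The compounds shown leave open whether an amine, a carboxylic acid or a longer chain at this same place would move the number on either core. They also leave open whether such a step would match between the two cores.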